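Cytotoxicity Outlook for a Thiazolyl Replacement

This account rests on a few compounds, and the source may have more. Where it says the series, first, only, none or still open, it means among the compounds named here.

Compound 1 `OCCCNc1nc(NCc2ccccc2)c2ccccc2n1` — > 10000 nM
Compound 2 `Oc1cccc(Nc2nc(NCc3ccccc3)c3ccccc3n2)c1` — 10000 nM

In an ADME assay on C2C12 cells (Mus musculus) for cytotoxicity (on this read-out higher numbers stand for lower toxicity in this test and lower numbers for higher toxicity in this test), compound 1 returns only a limit, > 10000 nM, so its position is known just as a bound and not as a number. Compound 2 gives 10000 nM in this assay. For the measured compounds named here, the one measured step, a number no higher from compound 1 to compound 2 (the limit leaves the size open), cannot be sized because of the limit of > 10000 nM in this assay, at which 1 of the 2 values shown sits.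

Compound 3 `c1ccc(CNc2nc(Nc3nccs3)nc3ccccc23)cc1` has not yet been measured in this assay. It differs from compound 1 by 1,3-thiazol-2-yl in place of 3-hydroxypropyl on a nitrogen on an aromatic ring. The measured step bears on it only loosely: there too the 3-hydroxypropyl on the nitrogen gave way to an aromatic ring, and the value did not move to a readable degree. With compound 1 sitting at the limit and compound 2 sitting at the same number, no change beyond the usual scatter is expected here, and the result may well again be reported only as a limit.

Compound 3 is therefore estimated at 10000 nM, with a likely range from 3000 nM to 30000 nM. The step expected for this change is a number no higher from compound 1 to compound 3 (the limit leaves the size open).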

Compound 3, half-maximal cytotoxic concentration: > 10000 nM
Compound 3 was reported as a limit (the forecaster's own chance of this, stated with the estimate: 60%); the middle value sits exactly at the limit.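

In this assay, compound 3 gives > 10000 nM, which is a limit and not a number. The new result shows that the nitrogen on the aromatic ring can carry 1,3-thiazol-2-yl, a five-membered aromatic ring with 2 hetero atoms, and the read-out still stops at a limit, as it does with 3-hydroxypropyl in compound 1. For the compounds shown here, the only number in the set remains that of compound 2, at 10000 nM. Putting 1,3-thiazol-2-yl in place of 3-hydroxyphenyl on that nitrogen gives a number no lower from compound 2 to compound 3 (the limit leaves the size open). Neither new step can be read in size, because the values involved rest on the assay limit: the limit of > 10000 nM in this assay, at which 2 of the 3 values shown sit.

The compounds shown leave open how far compound 1 and compound 3 lie beyond their limits, and so whether the 1,3-thiazol-2-yl and 3-hydroxypropyl groups differ at all in this read-out. They also leave open whether a carboxylic acid, a primary amine or a longer alkyl chain on the same nitrogen would give a value that could be read as a number in this assay.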